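The source may report more compounds than this note shows. Statements on the series, on what has been measured and on what is new or still open speak of the compounds shown alone.

Compound 1 `CC(C)(C)c1ccc(C(CC(=O)O)NC(=O)c2c(Cl)cccc2Cl)cc1` opens the set. In a functional assay on MDA-MB-436 cells (Homo sapiens) for antiproliferative activity, read by MTT assay, with a stated time of 24 h (on this read-out lower numbers stand for stronger inhibition and higher numbers for weaker inhibition), compound 1 gives only a limit, > 100000 nM. Compound 2 `CC(C)(C)c1ccc(C(CC(=O)O)NC(=O)c2ccc(Cl)cc2Cl)cc1` carries 2,4-dichlorophenyl in place of 2,6-dichlorophenyl on a carbonyl carbon. In this assay compound 2 likewise reaches only a limit, > 100000 nM. The step that the two limits leave unreadable from compound 1 to compound 2 cannot be read in size because the limit of > 100000 nM in this assay, at which 3 of the 3 values shown sit, holds both of its ends. Compound 3 `O=C(O)CC(NC(=O)c1c(Cl)cccc1Cl)c1ccc(Cl)cc1Cl` keeps the 2,6-dichlorophenyl on the carbonyl carbon seen in compound 1, but the difference between the two cores is not broken down here. In this assay compound 3 again stops at a limit, > 100000 nM. Compound 4 `O=C(O)CC(NC(=O)c1ccc(Cl)cc1Cl)c1ccc(Cl)cc1Cl` has not yet been measured; it differs from compound 3 by 2,4-dichlorophenyl in place of 2,6-dichlorophenyl on a carbonyl carbon, the same change that separates compound 1 from compound 2, made at the same place. Since every value so far sits at the limit of > 100000 nM in this assay, at which 3 of the 3 values shown sit, nothing among these compounds points to a direction for that change. The analyst expects the step that the limit leaves unreadable from compound 3 to compound 4 to leave compound 4 at the limit as well. The estimate for compound 4 in this assay is 150000 nM, expected to fall between 50000 nM and 500000 nM.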

Compound 4, half-maximal inhibitory concentration: 57300 nM
The estimate for compound 4 lay 2.6-fold (0.42 log units) above the measured number; measured number inside the range.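

In this assay, exchanging the one dichlorophenyl group on the carbonyl carbon for the other gives an at least 1.7-fold lower number from compound 3 to compound 4 (0.24 log units; that floor lies within the scatter), and compound 4 is the only compound shown with a number rather than a limit. This supports no firm direction even on this core, as the floor of the step lies within the scatter, although the true step may be larger. The same change on the core of compound 1 does not show whether the result carries from one core to the other, because neither end of that step can be read: the limit of > 100000 nM in this assay, at which 3 of the 4 values shown sit.

Going by these compounds, whether a methyl ester in place of the carboxylic acid would bring either core to a readable number in this assay stays open. So does whether a trifluoromethyl group in place of the chlorine atoms on the benzoyl part would give a step that could be compared across the two cores.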